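Compound 2 to compound 4: a ring exchange

The source may report more compounds than this note shows. Statements on the series, on what has been measured and on what is new or still open speak of the compounds shown alone.

In an ADME assay on the whole organism (strain Sprague-Dawley) for metabolic stability, with Rattus norvegicus as the target, read by LC-MS (on this read-out lower numbers stand for a shorter-lived compound and higher numbers for a longer-lived compound), compound 2 `O=C1NCCN1CCOc1nn(-c2ccccc2F)c2ccc(F)cc12` gives 0.4 h, level with compound 1 `O=c1[nH]ccn1CCOc1nn(-c2ccccc2F)c2ccc(F)cc12` at 0.4 h. Compound 3 `O=C1NCCN1CCOc1nn(-c2ccc(F)cc2)c2ccc(F)cc12` gives 0.7 h, which is a 1.8-fold higher number from compound 2 to compound 3 (0.24 log units; within the scatter). The next structure, compound 4 `Fc1ccc2c(c1)c(OCCn1ccnc1)nn2-c1ccccc1F`, carries 1H-imidazol-1-yl in place of 2-oxoimidazolidin-1-yl on a saturated chain carbon, two bonds along the chain from an oxygen on an aromatic ring, on a saturated chain carbon. The closest evidence is no change at the digits printed from compound 1 to compound 2 (within the scatter), an exchange of five-membered rings at the same place. The other measured step, a 1.8-fold higher number from compound 2 to compound 3 (0.24 log units; within the scatter), lies on an aromatic nitrogen and bears on this change only indirectly. For the measured compounds named here, no measured compound holds the 1H-imidazol-1-yl group. No shift beyond the scatter is expected in this assay, the estimated step being no change at the digits printed from compound 2 to compound 4 (within the scatter). Compound 4 is expected at 0.4 h, with an estimated range of 0.2 h to 0.8 h.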

Compound 4, half-life: 1.1 h
Estimate against measurement, compound 4: 2.8-fold (0.44 log units) below, and the stated range ends below it.
By their numbers in this assay, from the lowest: compounds 1, 2, 3 and 4 (each within the scatter of the next, the first and the last beyond it).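

In this assay, 1H-imidazol-1-yl on this saturated chain carbon brings a shift beyond the scatter, seen as a 2.8-fold higher number from compound 2 to compound 4 (0.44 log units; beyond the scatter) and as a 2.8-fold higher number from compound 1 to compound 4 (0.44 log units; beyond the scatter) in the second comparison, whereas the ring exchange at the same place gave no change at the digits printed from compound 1 to compound 2 (within the scatter) for the groups of 6 heavy atoms. An aromatic five-membered ring alone does not set the number, since compound 1 and compound 4 both carry one, and the step between them removes the oxygen. Nothing measured accounts for this shift. Open, on these data alone, is whether a 4-fluorophenyl on the aromatic nitrogen keeps this step, and whether a 1H-pyrazol-1-yl or a dimethylamino group at this place reads the same way.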